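The source may hold more compounds than are shown below. What is called first, only, known or untested is meant among the compounds shown, and "the series" means these compounds.

Of the compounds shown here, three have so far been tested in a functional assay on K562 cells (Homo sapiens) for inhibition, read by sulforhodamine B assay, with a stated time of 48 h (on this read-out lower numbers stand for higher toxicity in this test and higher numbers for lower toxicity in this test), and each returned only a limit of the test rather than a number. Compound 1 `CCOC(=O)[C@H](CCC(=O)O)NC(=O)c1ccc(Sc2nc3cc(N)cc(N)c3nc2-c2ccccc2)cc1` gives < 100000 nM, which is such a limit. Compound 3 `CCOC(=O)[C@H](CCC(=O)O)NC(=O)c1ccc(CNc2nc3cc(N)cc(N)c3nc2-c2ccccc2)cc1` gives < 100000 nM, also a limit. Compound 2 `Nc1cc(N)c2nc(-c3ccccc3)c(Sc3ccc(F)cc3)nc2c1` gives < 100000 nM, again a limit, and this is where every value sits (the limit of < 100000 nM in this assay, at which 3 of the 3 values shown sit). Compound 4 `Nc1cc(N)c2nc(-c3ccccc3)c(NCc3ccc(F)cc3)nc2c1` has not been measured yet. It differs from compound 2 by (4-fluorobenzyl)amino in place of (4-fluorophenyl)sulfanyl on an aromatic carbon. Among the compounds with values here, no measured pair differs in only one place, so nothing sets the size of this step. With all three values at the limit, the expected step that the limit leaves unreadable from compound 2 to compound 4 is none beyond the scatter. Compound 4 is therefore estimated at 60000 nM, somewhere between 15000 nM and 100000 nM.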

Compound 4, concentration lethal to 50% of the cells: < 100000 nM
Compound 4: only a limit was reported; the forecaster's own chance of this, stated with the estimate: 70%; the middle value does not contradict the limit.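

Compound 2 and compound 4 each returned only a limit in this assay, so no step can be read between them: the limit of < 100000 nM in this assay, at which 4 of the 4 values shown sit.

The compounds shown leave open what any actual value is, and whether (4-fluorobenzyl)amino in place of (4-fluorophenyl)sulfanyl changes the read-out at all.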